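A few compounds are considered here, and "the series" means these few. Any claim that something is new, unique, unknown or untested is made for them only; others in the source may bear on it.

Working notes on a small set of three diaryl-substituted compounds sharing one core, tested in a functional assay on T47D cells (Homo sapiens) for inhibition; on this read-out higher numbers stand for weaker inhibition and lower numbers for stronger inhibition. Compound 1 `Oc1cccc(-c2cc(-c3ccc(F)cc3)cc(-c3ccccc3O)n2)c1` carries a 2-hydroxyphenyl group; in this assay compound 1 gives > 50000 nM, which is a limit of the assay rather than a number, namely (the limit of > 50000 nM in this assay, at which 1 of the 3 values shown sits). Compound 2 `Oc1cccc(-c2cc(-c3ccc(F)cc3)cc(-c3cccc(O)c3)n2)c1`, with a 3-hydroxyphenyl group in its place, gives 6870 nM in this assay, and compound 3 `Oc1ccc(-c2cc(-c3ccc(F)cc3)cc(-c3cccc(O)c3)n2)cc1`, with a 4-hydroxyphenyl group there, gives 5000 nM. The steps from the 2-hydroxyphenyl compound are clear: an at least 7.2-fold lower number from compound 1 to compound 2 (0.86 log units; beyond the scatter) and an at least 10-fold lower number from compound 1 to compound 3 (1.00 log units; beyond the scatter). Between the two hydroxyphenyl isomers the difference is small: a 1.4-fold lower number from compound 2 to compound 3 (0.14 log units; within the scatter). Compound 3 therefore holds the lowest of the two numbers, with compound 2 as its nearest neighbour, inside the scatter.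

Compound 4 `Oc1ccc(-c2cc(-c3ccc(F)cc3)cc(-c3ccc(O)cc3)n2)cc1` has the same atoms as compound 3 joined differently: 4-hydroxyphenyl in place of 3-hydroxyphenyl on an aromatic carbon. The same exchange, 3-hydroxyphenyl for 4-hydroxyphenyl, has already been measured once in this series, as the step from compound 2 to compound 3, and it stayed within the scatter. The expectation for compound 4 in this assay is accordingly a step of a 1.3-fold lower number from compound 3 to compound 4 (0.10 log units; within the scatter), that is no change beyond the scatter, perhaps a slightly lower number. Compound 4 is thus estimated at 4000 nM, within a range of 1500 nM to 11000 nM.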

Compound 4, half-maximal inhibitory concentration: 5260 nM
Compound 4: middle estimate off by 1.3-fold (0.12 log units), on the low side; measured number inside the range.
By their numbers in this assay, from the lowest: compounds 3, 4 and 2 (each within the scatter of the next). At a limit, above all of these: compound 1.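

In this assay, the exchange of 3-hydroxyphenyl for 4-hydroxyphenyl on the aromatic carbon next to the ring nitrogen now has a second reading, this time with a 4-hydroxyphenyl group as the partner at the other substituted carbon: a 1.1-fold higher number from compound 3 to compound 4 (0.02 log units; within the scatter). Compound 2 to compound 3 had shown the exchange only with a 3-hydroxyphenyl partner, so within compounds 2, 3 and 4 the choice between these two hydroxyphenyl groups gives no step beyond the scatter, whichever partner is present. Compound 1, with its 2-hydroxyphenyl group, goes against this flat pattern and remains a limit rather than a number: the limit of > 50000 nM in this assay, at which 1 of the 4 values shown sits.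

The compounds shown leave open whether the hydroxyl is needed at all, since a plain phenyl, a methoxyphenyl or an aminophenyl group at this position would be required to test it. They also leave open how the numbers respond at the 4-fluorophenyl position, for instance to a 4-chlorophenyl group or to a pyridine ring in its place.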